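A few compounds are considered here, and "the series" means these few. Any claim that something is new, unique, unknown or untested is made for them only; others in the source may bear on it.

Compound 1 `OC[C@H]1O[C@@H](n2cnc3c(NCc4ccccc4F)ncnc32)[C@H](O)[C@@H]1O`: 33200 nM
Compound 2 `OC[C@H]1O[C@@H](n2cnc3c(NCc4ccccc4Br)ncnc32)[C@H](O)[C@@H]1O`: 10000 nM
Compound 3 `OC[C@H]1O[C@@H](n2cnc3c(NCc4cccc(Br)c4)ncnc32)[C@H](O)[C@@H]1O`: 19700 nM

In a functional assay on K562 cells (Homo sapiens) for antiproliferative activity, with a stated time of 72 h (on this read-out lower numbers stand for stronger inhibition and higher numbers for weaker inhibition), compound 3 gives 19700 nM, the second highest of the three numbers; it lies within the scatter of compound 1, a step of a 1.7-fold lower number from compound 1 to compound 3 (0.23 log units; within the scatter), and also within the scatter of compound 2, a step of a 2.0-fold higher number from compound 2 to compound 3 (0.29 log units; within the scatter). Compound 4 `OC[C@H]1O[C@@H](n2cnc3c(NCc4ccc(F)c(F)c4F)ncnc32)[C@H](O)[C@@H]1O` differs from compound 3 in one place: 2,3,4-trifluorophenyl in place of 3-bromophenyl on a saturated chain carbon bound to a nitrogen on an aromatic ring. The step that bears most on this is a 3.3-fold lower number from compound 1 to compound 2 (0.52 log units; beyond the scatter), a modest change where bromo gave the lower number and fluoro the higher. Among the compounds with values here, no step shows a 2,3,4-trifluorophenyl, so the bearing of three fluorines is unknown. Compound 4 is therefore expected to give a number near or somewhat above compound 3, a step of a 1.3-fold higher number from compound 3 to compound 4 (0.10 log units; within the scatter), estimated at 25000 nM with a range from 8000 nM to 80000 nM.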

Compound 4, half-maximal inhibitory concentration: > 166000 nM
Compound 4: no number, only a limit (the forecaster's own chance of this, stated with the estimate: 10%); middle value at least 6.6-fold (0.82 log units) away from the limit.
By their numbers in this assay, from the lowest: compounds 2, 3 and 1 (each within the scatter of the next, the first and the last beyond it). At a limit, above all of these: compound 4.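

In this assay the change to 2,3,4-trifluorophenyl on a saturated chain carbon bound to a nitrogen on an aromatic ring gives an at least 8.4-fold higher number from compound 3 to compound 4 (0.92 log units; beyond the scatter) and an at least 16-fold higher number from compound 2 to compound 4 (1.22 log units; beyond the scatter) and also an at least 5.0-fold higher number from compound 1 to compound 4 (0.69 log units; beyond the scatter) in the three comparisons. The earlier compounds shown here showed only small to modest shifts at this position, whereas this change alone moves the read-out far further. Compound 4 reads only as a limit and not as a number: the limit of > 166000 nM in this assay, at which 1 of the 4 values shown sits. The compounds shown leave open whether the number of fluorines or their placement on the ring carries this change. From the compounds shown here alone, how a methoxy group, an amine or a longer chain would read at this position also stays open.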